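Replacing a ring carbamate with a fluorinated alkyl group on compound 3

This account rests on a few compounds, and the source may have more. Where it says the series, first, only, none or still open, it means among the compounds named here.

Measured compounds:
compound 1 `Cc1nc(S(C)(=O)=O)ccc1O[C@H]1CC[C@H](OC2CCN(C(=O)OC(C)C)CC2)CC1`: 89 nM
compound 2 `CC(C)(C)OC(=O)N1CCC(O[C@H]2CC[C@H](Oc3ccc(S(C)(=O)=O)nn3)CC2)CC1`: 1160 nM
compound 3 `CC1(OC(=O)N2CCC(O[C@H]3CC[C@H](Oc4cnc(S(C)(=O)=O)cn4)CC3)CC2)CC1`: 138 nM

In a functional assay on isolated protein for agonist activity at Glucose-dependent insulinotropic receptor (Rattus norvegicus), read by HTRF and cAMP accumulation (on this read-out higher numbers stand for an effect only at larger amounts of compound and lower numbers for an effect already at smaller amounts), compound 3 gives 138 nM, the second highest of the three numbers. Compound 1 is nearest, with a number within the scatter of that of compound 3, whereas compound 2 gives 1160 nM, a number beyond the scatter and clearly higher than that of compound 3.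

Compound 4 `CS(=O)(=O)c1cnc(O[C@H]2CC[C@H](OC3CCN(CC4(C(F)(F)F)CCCC4)CC3)CC2)cn1` differs from compound 3 at one place: a group of 10 heavy atoms (7 carbon, 3 fluorine; one five-membered non-aromatic ring of carbon only) in place of a group of 7 heavy atoms (5 carbon, 2 oxygen; one three-membered non-aromatic ring of carbon only), on an amine nitrogen in a ring. Among the compounds with values here, no measured pair shows such a change, so the expectation rests on the change itself. The account expects a modest step upward, a 2.2-fold higher number from compound 3 to compound 4 (0.34 log units; beyond the scatter), with wide uncertainty. Compound 4 is thus estimated at 300 nM, with a range from 80 nM to 1200 nM.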

Compound 4, half-maximal effective concentration: 101 nM
For compound 4 the middle estimate is 3.0-fold (0.47 log units) above the measured one; the measured number falls inside the stated range.
By their numbers in this assay, from the lowest: compounds 1, 4 and 3 (each within the scatter of the next); then compound 2.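

In this assay the amine nitrogen in the ring accepts a carbon-and-fluorine group in place of the ((1-methylcyclopropyl)oxy)carbonyl group, with a 1.4-fold lower number from compound 3 to compound 4 (0.14 log units; within the scatter) and no loss of the effect. For this pair, then, neither the carbonyl nor the carbamate oxygens are needed on this read-out, since the entering group has no hydrogen-bond acceptors. No measurement shown gives a reason for this result.

On these data alone, it remains open which part of the entering group, the trifluoromethyl or the five-membered ring, carries the effect. As far as these compounds go, a benzyl group or a plain ethyl chain on this nitrogen also stays untested here.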